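This account rests on a few compounds, and the source may have more. Where it says the series, first, only, none or still open, it means among the compounds named here.

Measured compounds in a functional assay on A549 cells (Homo sapiens) for antiproliferative activity, read by MTT assay, with a stated time of 72 h; on this read-out higher numbers stand for weaker inhibition and lower numbers for stronger inhibition:
Compound 1 `CS(=O)(=O)c1ccc(C(=O)Nc2ccc(Cl)c(-c3nnc4c(Cl)cccn34)c2)c(Cl)c1` — in this assay compound 1 gives > 100000 nM, which is a limit of the assay and not a number.
Compound 2 `O=C(Nc1ccc(Cl)c(-c2nnc3c(Cl)cccn23)c1)c1ccccc1` — in this assay compound 2 gives 76900 nM.
Compound 3 `O=C(Nc1ccc(Cl)c(-c2nnc3c(Cl)cccn23)c1)c1ccccc1Cl` — in this assay compound 3 gives > 100000 nM, again only a limit.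

Compound 3 therefore stands at the ceiling of the series, where two of the three values sit (the limit of > 100000 nM in this assay, at which 2 of the 3 values shown sit). The step of an at least 1.3-fold higher number from compound 2 to compound 3 (0.11 log units; that floor lies within the scatter) stays within scatter, and a step that the two limits leave unreadable from compound 1 to compound 3 cannot be read. Compound 4 `O=C(Nc1ccc(Cl)c(-c2nnc3c(Cl)cccn23)c1)c1ccon1` carries the change (1,2-oxazol-3-yl in place of 2-chlorophenyl on a carbonyl carbon). For the measured compounds named here, no measured step touches the acyl ring itself, so this change has no precedent among the three compounds. Compound 4 is expected to remain near the limit, estimated at 100000 nM with a range from 30000 nM to 300000 nM. The expected step of a number no higher from compound 3 to compound 4 (the limit leaves the size open) is read as no change beyond the scatter.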

Compound 4, half-maximal inhibitory concentration: 42700 nM
For compound 4 the middle estimate is 2.3-fold (0.37 log units) above the measured one; measured number inside the range.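

In this assay, for the compounds shown here, the first change of the ring itself on the carbonyl carbon, 1,2-oxazol-3-yl in place of 2-chlorophenyl, gives an at least 2.3-fold lower number from compound 3 to compound 4 (0.36 log units; beyond the scatter). Against unsubstituted phenyl, the same ring gives a 1.8-fold lower number from compound 2 to compound 4 (0.26 log units; within the scatter), so the change is readable only against 2-chlorophenyl and compound 4 cannot be separated from compound 2. The first step has only a floor, as compound 3 stands at a limit of the assay and not at a number: the limit of > 100000 nM in this assay, at which 2 of the 4 values shown sit.

Open, as far as these compounds go, is whether other five-membered aromatic rings on the carbonyl carbon read like 1,2-oxazol-3-yl. Also open, from the compounds shown here alone, is what an amine or a carboxylic acid on that ring would do.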